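Purine series: amino for chloro, cytotoxicity in melanoma cells

This account rests on a few compounds, and the source may have more. Where it says the series, first, only, none or still open, it means among the compounds named here.

Measured compounds:
compound 1 `Nc1nc(Cl)c2ncn(Cc3ccc(CCl)cc3)c2n1`, 11500 nM
compound 2 `ClCc1cccc(Cn2cnc3c(Cl)nc(Cl)nc32)c1`, 1990 nM
compound 3 `ClCc1ccc(Cn2cnc3c(Cl)nc(Cl)nc32)cc1`, 20000 nM

All three were tested in a functional assay on SK-MEL-2 cells (Homo sapiens) for cytotoxicity, read by sulforhodamine B assay, with a stated time of 48 h; a lower number here means a stronger inhibitor of growth, a higher number a weaker inhibitor of growth. Compound 3 `ClCc1ccc(Cn2cnc3c(Cl)nc(Cl)nc32)cc1` gives 20000 nM, and compound 1 `Nc1nc(Cl)c2ncn(Cc3ccc(CCl)cc3)c2n1`, which carries the change (amino in place of chloro on an aromatic carbon), gives 11500 nM. The step of a 1.7-fold lower number from compound 3 to compound 1 (0.24 log units; within the scatter) is small and does not separate the two compounds.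

Compound 2 `ClCc1cccc(Cn2cnc3c(Cl)nc(Cl)nc32)c1` gives 1990 nM, the lowest of the three numbers, with both compound 1 and compound 3 beyond the scatter above it. Compound 2 and compound 3 are built from the same atoms joined differently; the difference between the two cores is not broken down here.

Compound 4 `Nc1nc(Cl)c2ncn(Cc3cccc(CCl)c3)c2n1` has not yet been measured in this assay. It stands to compound 2 as compound 1 stands to compound 3: the change (amino in place of chloro on an aromatic carbon). The two place descriptions agree word for word, so this is the same change. Going by the values given here, the only measured instance of it, a 1.7-fold lower number from compound 3 to compound 1 (0.24 log units; within the scatter), lies within the scatter. On that basis the step expected from compound 2 to compound 4 is a 1.4-fold lower number from compound 2 to compound 4 (0.15 log units; within the scatter), also small, because it rests on a 1.7-fold lower number from compound 3 to compound 1 (0.24 log units; within the scatter) alone. Compound 4 is accordingly estimated at 1400 nM in this assay, with an expected range from 500 nM to 4500 nM.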

Compound 4, concentration for 50% growth inhibition: 10700 nM
The estimate for compound 4 lay 7.6-fold (0.88 log units) below the measured number; the whole stated range lies below it.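

In this assay, amino in place of chloro on an aromatic carbon gives a 5.4-fold higher number from compound 2 to compound 4 (0.73 log units; beyond the scatter), so the change does not behave here as it did in its earlier instance. Set side by side, the two instances differ, and the outcome of this change on one core cannot be taken as a guide to its outcome on the other: the same change on two cores in this assay, a 1.7-fold lower number (0.24 log units; within the scatter) from compound 3 to compound 1 and a 5.4-fold higher number (0.73 log units; beyond the scatter) from compound 2 to compound 4, 9.4-fold (0.97 log units) apart, beyond the scatter of two such steps. These two pairs show that the step can depend on the core, but they do not show what in the cores produces the difference, and they give no rule for any further core in the series.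

The compounds shown leave open whether the larger step on the core of compound 2 is particular to amino or would also appear with a methylamino or methoxy group on the same aromatic carbon. They also leave open how either core would respond if a dimethylamino group or a longer amine chain stood on that carbon, which would show whether the two cores continue to part ways beyond this single pair of groups.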